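Aryl substituent removal in the pentyl-linked piperazine series

This account rests on a few compounds, and the source may have more. Where it says the series, first, only, none or still open, it means among the compounds named here.

Compound 2 `O=c1[nH]c2ccccc2n1CCCCCN1CCN(c2cccc(Cl)c2)CC1` gives 11 nM in an assay on HEK293 cells for displacement of a labelled ligand from 5-hydroxytryptamine receptor 7 (Homo sapiens) (a higher number here means a weaker inhibitor, a lower number a stronger inhibitor), the lowest of the three numbers recorded. Compound 1 `COc1ccccc1N1CCN(CCCCCn2c(=O)[nH]c3ccccc32)CC1` gives 38 nM in this assay, and compound 3 `O=c1[nH]c2ccccc2n1CCN1CCN(c2ccccc2)CC1`, which carries a short two-carbon chain between the shared core and the piperazine, gives 1030 nM. Within the data shown here, the one step that compares aryl substituents on the piperazine nitrogen, a 3.5-fold lower number from compound 1 to compound 2 (0.54 log units; beyond the scatter), is modest yet beyond the scatter.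

Compound 4 `O=c1[nH]c2ccccc2n1CCCCCN1CCN(c2ccccc2)CC1` differs from compound 2 by hydrogen in place of chloro on an aromatic carbon. Among the measured compounds shown here, no measured pair in this set removes a substituent from the aryl ring outright; the only relevant step is the exchange of 2-methoxyphenyl for 3-chlorophenyl from compound 1 to compound 2, which shows that the group on that ring shifts the number by a modest amount. Taking the bare phenyl as likely to sit between the two substituted analogues or somewhat weaker, a modest rise in this assay is expected, with the scatter leaving an unchanged value possible. Compound 4 is therefore estimated at 40 nM, within 12 nM to 130 nM, a step of a 3.6-fold higher number from compound 2 to compound 4 (0.56 log units; beyond the scatter).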

Compound 4, inhibition constant: 6 nM
The estimate for compound 4 lay 6.7-fold (0.82 log units) above the measured number, outside the stated range (below it).
By their numbers in this assay, from the lowest: compounds 4 and 2 (each within the scatter of the next); then compound 1; then compound 3.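

The chloro on this aromatic carbon, meta to a large group, can go without a change that can be read in this assay (a 1.8-fold lower number from compound 2 to compound 4 (0.26 log units; within the scatter)), so the bare phenyl holds its place alongside the 3-chlorophenyl of compound 2. The 2-methoxyphenyl of compound 1 now stands apart from both, with a modest step beyond the scatter on its replacement by hydrogen (a 6.3-fold lower number from compound 1 to compound 4 (0.80 log units; beyond the scatter)), which makes the methoxy, and not the chloro, the substituent that separates these pentyl-linked compounds. Among these compounds, compound 4 also forms the first pair that differs only in the chain: with the same phenyl on the piperazine, compound 3 on the shorter chain gives 1030 nM while compound 4 on the pentyl chain gives 6 nM.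

A fluoro, a trifluoromethyl or a methoxy on the aromatic carbon that carries the chloro in compound 2 would show whether this carbon accepts groups other than chloro. A butyl chain on the compound 4 structure would show how the numbers run between the two chain lengths. No measurement in hand accounts for any of these numbers.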